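A few compounds are considered here, and "the series" means these few. Any claim that something is new, unique, unknown or untested is made for them only; others in the source may bear on it.

Compound 1, with structure `CCNc1cc(-c2ccc(NC(=O)Nc3c(C)cccc3C)cc2C)ccn1`, compound 2, `CCNc1cc(-c2ccc(NC(=O)Nc3ccccc3Cl)cc2C)ccn1`, and compound 3, `CCNc1cc(-c2ccc(NC(=O)Nc3c(C)cccc3C)cc2C(F)(F)F)ccn1`, were each tested in an assay on isolated protein for inhibition of serine/threonine-protein kinase PLK1 (Homo sapiens), read by radiometric assay and 33P incorporation, with a stated time of 40 min, tested at 20 uM, in the presence of a further agent that is not named here; a higher number here means more inhibition at the concentration tested (going by the name of the read-out), a lower number less inhibition. Compound 1 gives 42.1%, compound 2 gives 49.2%, and compound 3 gives 59.2%. Compound 2 differs from compound 1 by a single change, (2-chlorophenyl in place of 2,6-dimethylphenyl on an amide-type nitrogen), and that change made a step of a number 7.1 percentage points higher from compound 1 to compound 2 (within the scatter). Compound 3 differs from compound 1 in a different place, and that change made a step of a number 17.1 percentage points higher from compound 1 to compound 3 (beyond the scatter).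

Compound 4, `CCNc1cc(-c2ccc(NC(=O)Nc3ccccc3Cl)cc2C(F)(F)F)ccn1`, has not yet been measured in this assay. It differs from compound 3 by 2-chlorophenyl in place of 2,6-dimethylphenyl on an amide-type nitrogen, which is the same change that turned compound 1 into compound 2, now made on the core of compound 3 rather than on the core of compound 1; the two cores differ by trifluoromethyl in place of methyl on an aromatic carbon. Because the earlier step of this change, a number 7.1 percentage points higher from compound 1 to compound 2 (within the scatter), stayed within the scatter, a similar small step is expected here, a number 4.8 percentage points higher from compound 3 to compound 4 (within the scatter). Compound 4 is therefore estimated at 64%, most likely falling between 50% and 78%.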

Compound 4, a percentage reported as inhibition, at one concentration (the size of the read-out at that concentration, not a potency): 71.6%
Compound 4: middle estimate off by 7.6 percentage points, on the low side, within the range that was stated.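

In this assay, putting 2-chlorophenyl in place of 2,6-dimethylphenyl on the amide-type nitrogen of the trifluoromethyl core gave a step of a number 12.4 percentage points higher from compound 3 to compound 4 (beyond the scatter), and this step agrees with the one seen on the methyl core: the same change on two cores in this assay, a number 7.1 percentage points higher (within the scatter) from compound 1 to compound 2 and a number 12.4 percentage points higher (beyond the scatter) from compound 3 to compound 4, 5.3 percentage points apart, within the scatter of two such steps. Likewise, trifluoromethyl in place of methyl gave a step of a number 22.4 percentage points higher from compound 2 to compound 4 (beyond the scatter), which agrees with its counterpart on the other core: the same change on two cores in this assay, a number 17.1 percentage points higher (beyond the scatter) from compound 1 to compound 3 and a number 22.4 percentage points higher (beyond the scatter) from compound 2 to compound 4, 5.3 percentage points apart, within the scatter of two such steps. Each change therefore carried over between these two cores with a similar step size, but this rests on just four compounds, each read at a single concentration, and it does not show that the same would hold on any other core or explain why the steps match.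

The compounds shown leave open whether a nitrile in place of the trifluoromethyl group would fit the same picture. They also leave open what a longer chain in place of the ethyl group on the amine would do to the inhibition.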